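A few compounds are considered here, and "the series" means these few. Any claim that something is new, unique, unknown or untested is made for them only; others in the source may bear on it.

In a functional assay on the whole organism for inhibition, with Rattus norvegicus as the target, read by paw edema, with a stated time of 30 min, at a dose of 80 mg/kg by the oral route; on this read-out higher numbers stand for a stronger effect at the one dose given and lower numbers for a weaker effect:
compound 1 `Brc1ccccc1OCC1=NCCO1`: 62.8%
compound 2 `Cc1ccccc1OCC1=NCCO1`: 55.3%

Compound 2 stands at the lower of the two readings, though the step of a number 7.5 percentage points lower from compound 1 to compound 2 (within the scatter) shows that this difference is within the scatter, so compound 1 and compound 2 cannot be told apart on these numbers.

Compound 3 `Cc1ccc(OCC2=NCCO2)c(C)c1` is not yet measured. It differs from compound 2 by methyl in place of hydrogen on an aromatic carbon. Within the data shown here, the only measured step, a number 7.5 percentage points lower from compound 1 to compound 2 (within the scatter), concerns the exchange of one group for another at a single place rather than the entry of a methyl where a hydrogen stood, so it bears on the present change only loosely. Among the measured compounds shown here, that step was within the scatter, and nothing so far has moved beyond it. No shift beyond the scatter is therefore expected for compound 3 in this assay. The expected step from compound 2 is a number 0.7 percentage points higher from compound 2 to compound 3 (within the scatter), essentially flat. Compound 3 is estimated at 56%, with a range from 42% to 70%.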

Compound 3, a percentage reported as inhibition, in the whole organism at one dose (the size of the read-out at that dose, not a potency): 85.5%
The estimate for compound 3 lay 29.5 percentage points below the measured number, outside the stated range (above it).
By their numbers in this assay, from the lowest: compounds 2 and 1 (each within the scatter of the next); then compound 3.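

In this assay, among these compounds, methyl in place of hydrogen gives a number 30.2 percentage points higher from compound 2 to compound 3 (beyond the scatter), the only step so far that lies beyond the scatter. The aromatic carbon meta to a methyl group and para to the group of 7 heavy atoms is therefore a place where one added carbon changes the read-out at this dose, which the earlier exchange of bromo for methyl, a number 7.5 percentage points lower from compound 1 to compound 2 (within the scatter), could not show. The data on hand offer no explanation for this gain, and the read-out remains the size of an effect at one dose, not a potency.

The compounds shown leave open whether the gain belongs to methyl as such or would also come with chloro, methoxy, an amine or a longer chain such as ethyl on the same carbon. Also open, from the compounds shown here alone, is whether the same methyl gives a step of like size on the core of compound 1, where bromo stands in place of the first methyl, and whether the step holds at other doses or times.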